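Removing the chloro from the trimethoxy chalcone of compound 1

The source may report more compounds than this note shows. Statements on the series, on what has been measured and on what is new or still open speak of the compounds shown alone.

Compound 1, `COc1cc(/C=C/C(=O)c2cccc(-n3cc(-c4ccc(Cl)cc4)[nH]c3=O)c2)cc(OC)c1OC`: 12900 nM
Compound 2, `COc1cc(/C=C/C(=O)c2cccc(-n3cc(-c4ccccc4)[nH]c3=O)c2)ccc1O`: 3390 nM
Compound 3, `O=C(/C=C/c1cccc(O)c1)c1cccc(-n2cc(-c3ccc(Cl)cc3)[nH]c2=O)c1`: 2520 nM

In a functional assay on NCI-H322M cells (Homo sapiens) for inhibition (on this read-out lower numbers stand for stronger inhibition of growth and higher numbers for weaker inhibition of growth), compound 1 gives 12900 nM and stands highest of the three numbers. Compound 2 gives 3390 nM, a number that sits beyond the scatter below compound 1, and compound 3 gives 2520 nM, also beyond the scatter below compound 1. Within the data shown here, compound 2 and compound 3 each differ from compound 1 in more than one place, so no single step between measured compounds is available.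

Compound 4, `COc1cc(/C=C/C(=O)c2cccc(-n3cc(-c4ccccc4)[nH]c3=O)c2)cc(OC)c1OC`, has not yet been measured in this assay. It differs from compound 1 in one place: hydrogen in place of chloro on an aromatic carbon, on an aromatic carbon of a six-membered aromatic ring of carbon only, para to a large group. Compound 2 carries the same phenyl and gives a lower number than compound 1, but its other ring also differs, so that comparison cannot be read as the effect of the chloro alone.

Among the measured compounds shown here, with no clean step to lean on, compound 4 is expected to land somewhat below compound 1, with a step of a 1.8-fold lower number from compound 1 to compound 4 (0.27 log units; within the scatter), though a result within the scatter of compound 1 would not surprise. The estimate for compound 4 is 7000 nM, with a range from 2500 nM to 20000 nM.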

Compound 4, concentration for 50% growth inhibition: 2020 nM
Compound 4: the middle estimate sits 3.5-fold (0.54 log units) above what was measured; measured number outside the range, below it.
By their numbers in this assay, from the lowest: compounds 4, 3 and 2 (each within the scatter of the next); then compound 1.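

In this assay, among these compounds, the step of a 6.4-fold lower number from compound 1 to compound 4 (0.81 log units; beyond the scatter) is the first comparison here in which only one place changes, with hydrogen in place of chloro on an aromatic carbon and the rest of compound 1 kept intact. Among the compounds shown here, it therefore isolates what the earlier compounds could not: on this trimethoxy chalcone, the move from 4-chlorophenyl to phenyl alone is enough to give stronger inhibition of growth, and by more than the usual scatter of the read-out. The data describe the size and direction of this step but offer no account of its origin, as nothing shown bears on the reason for it.

It remains open whether the same change would give a step of similar size with the other chalcone rings, such as the hydroxy-substituted ring of compound 3, since the compounds shown offer this single pair only. Also open, as far as these compounds go, is how other groups at this place on the aromatic ring would compare with hydrogen and chloro, for instance fluoro, methoxy, an amine or a carboxylic acid.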